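The compounds below may be only part of what the source reports. "The series", "measured", "known", "first", "only" and "open" are said of these compounds alone.

Of the compounds shown here, three sharing one core have been measured so far. Compound 1 `COc1ccc2c(=O)c(/C=C/C(=O)Nc3cc(C)ccc3C)coc2c1` carries a 2,5-dimethylphenyl group on an amide-type nitrogen. In a functional assay (QGY7701 cells, Homo sapiens) for inhibition, read by MTT assay, with a stated time of 48 h (a higher number here means a weaker inhibitor, a lower number a stronger inhibitor), compound 1 gives only a limit, > 100000 nM, as noted under (the limit of > 100000 nM in this assay, at which 1 of the 3 values shown sits). Compound 2 `COc1cccc(NC(=O)/C=C/c2coc3cc(OC)ccc3c2=O)c1` puts a 3-methoxyphenyl group in that place and gives 39100 nM in this assay. Compound 3 `COc1ccc2c(=O)c(/C=C/C(=O)NCc3ccc(F)cc3)coc2c1` carries a 4-fluorobenzyl group there and gives 7960 nM in this assay, the lowest of the two numbers obtained; its nearest neighbour is compound 2, with a 4.9-fold lower number from compound 2 to compound 3 (0.69 log units; beyond the scatter), and the step from compound 1 runs further, an at least 12-fold lower number from compound 1 to compound 3 (1.09 log units; beyond the scatter).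

Compound 4 `COc1ccc2c(=O)c(/C=C/C(=O)Nc3ccc(Cl)cc3)coc2c1` has not yet been measured. It differs from compound 3 in one place: 4-chlorophenyl in place of 4-fluorobenzyl on an amide-type nitrogen. Among the compounds with values here, two measured steps bear on this change, since both the replacement of 2,5-dimethylphenyl and of 3-methoxyphenyl by 4-fluorobenzyl lowered the number (an at least 12-fold lower number from compound 1 to compound 3 (1.09 log units; beyond the scatter) and a 4.9-fold lower number from compound 2 to compound 3 (0.69 log units; beyond the scatter)), while between the two aryl groups themselves the difference was smaller (an at least 2.5-fold lower number from compound 1 to compound 2 (0.40 log units; beyond the scatter)). Returning to an aryl group on the nitrogen is therefore expected to raise the number in this assay, giving an estimated 3.8-fold higher number from compound 3 to compound 4 (0.58 log units; beyond the scatter). Compound 4 is thus expected to give about 30000 nM in this assay, within a range from 8000 nM to 120000 nM.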

Compound 4, half-maximal inhibitory concentration: > 100000 nM
Compound 4 gave a limit, no number (the forecaster's own chance of this, stated with the estimate: 25%); middle value at least 3.3-fold (0.52 log units) away from the limit.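

In this assay, 4-chlorophenyl in place of 4-fluorobenzyl on the amide-type nitrogen brings an at least 12-fold higher number from compound 3 to compound 4 (1.09 log units; beyond the scatter), and 4-chlorophenyl in place of 3-methoxyphenyl brings an at least 2.5-fold higher number from compound 2 to compound 4 (0.40 log units; beyond the scatter). The value of compound 4 is a limit and not a number, so both steps give only a least size, and the step involving compound 1, whose value is also a limit, cannot be read. With this result, the benzyl group of compound 3 gives the lowest number among one benzyl and three phenyl groups, while compound 2 goes against any simple split, as its phenyl group still gives a number and the two other phenyl groups do not: the limit of > 100000 nM in this assay, at which 2 of the 4 values shown sit.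

The compounds shown do not separate the change from benzyl to phenyl from the change from fluorine to chlorine, and 4-chlorobenzyl or 4-fluorophenyl on the same nitrogen would tell these two apart. They also leave open how a longer chain such as 2-phenylethyl, or a group carrying an amine, would read in this assay.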